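Indole in place of dichlorophenyl on the vinyl sulfone core

The compounds below may be only part of what the source reports. "The series", "measured", "known", "first", "only" and "open" are said of these compounds alone.

Compound 1 `O=C(/C(=C\c1ccc(Cl)cc1Cl)S(=O)(=O)c1ccc(Br)cc1)c1ccc(Br)cc1` gives 10000 nM in a functional assay on DU-145 cells (Homo sapiens) for inhibition, read by trypan blue exclusion, with a stated time of 96 h (a lower number here means a stronger inhibitor of growth, a higher number a weaker inhibitor of growth), and stands lowest of the two numbers measured; compound 2 `COc1ccc(S(=O)(=O)/C(=C/c2ccc(Cl)cc2Cl)C(=O)c2ccc(Br)cc2)cc1` gives 20000 nM, and the step of a 2.0-fold higher number from compound 1 to compound 2 (0.30 log units; within the scatter) came from methoxy in place of bromo on an aromatic carbon. Compound 3 `O=C(/C(=C\c1c[nH]c2ccccc12)S(=O)(=O)c1ccc(Br)cc1)c1ccc(Br)cc1` differs from compound 1 by 1H-indol-3-yl in place of 2,4-dichlorophenyl on a double-bonded chain carbon bound to a double-bonded chain carbon. Within the data shown here, no measured step touches this part of the shared core, so the only guide is that the one change tried elsewhere stayed within the scatter. Compound 3 is therefore expected near 10000 nM (range 3000 nM to 30000 nM), a step of no change at the digits printed from compound 1 to compound 3 (within the scatter) that is not estimated to exceed the scatter.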

Compound 3, concentration for 50% growth inhibition: 25000 nM
Compound 3: the middle estimate sits 2.5-fold (0.40 log units) below what was measured; measured number inside the range.
By their numbers in this assay, from the lowest: compounds 1, 2 and 3 (each within the scatter of the next, the first and the last beyond it).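

In this assay this is the first step shown that goes beyond the scatter: 1H-indol-3-yl in place of 2,4-dichlorophenyl gives a 2.5-fold higher number from compound 1 to compound 3 (0.40 log units; beyond the scatter) and so weakens growth inhibition modestly. The number therefore responds to the group on this double-bonded chain carbon, and the indole does not improve on the dichlorophenyl. No evidence at hand accounts for this step. Still open, going by these compounds, is whether a phenyl carrying an amine or a carboxylic acid would behave like either group, and whether a methyl on the indole nitrogen would change the number.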